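A few compounds are considered here, and "the series" means these few. Any claim that something is new, unique, unknown or untested is made for them only; others in the source may bear on it.

In an ADME assay on J774 cells (Mus musculus) for cytotoxicity (on this read-out lower numbers stand for an effect already at smaller amounts and higher numbers for an effect only at larger amounts of compound), compound 1 `COC(=O)c1c[nH]c2cc(OCCOc3ccccc3)ccc2c1=O` gives > 20000 nM, which is a limit and not a number. Compound 2 `CCCCc1cc2c(=O)c(C#N)c[nH]c2cc1OCCOc1ccccc1` gives > 20000 nM, also only a limit. Among the measured compounds shown here, the series so far therefore shows (the limit of > 20000 nM in this assay, at which 2 of the 2 values shown sit). Compound 3 `CCCCc1cc2c(=O)c(CC)c[nH]c2cc1OCCOc1ccccc1` has ethyl in place of cyano on an aromatic carbon. For the measured compounds named here, no measured step in this assay shows the effect of such a change. The expected step of a number no higher from compound 2 to compound 3 (the limit leaves the size open) is none beyond the scatter, and this expectation rests on compound 2 with its limit of > 20000 nM. Compound 3 is expected at 20000 nM, with an estimated range of 9000 nM to 40000 nM.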

Compound 3, half-maximal effective concentration: 360 nM
Estimate against measurement, compound 3: 56-fold (1.74 log units) above; the measured number lies below the stated range.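

In this assay, ethyl in place of cyano on an aromatic carbon gives an at least 55-fold lower number from compound 2 to compound 3 (1.74 log units; beyond the scatter), so the group at this position can decide whether cytotoxicity appears at all on the shared core. From the compounds shown here alone, compound 2 gives > 20000 nM, which is a limit, so the full size of the step stays unknown. Compound 3 is the only compound shown that comes off that limit: the limit of > 20000 nM in this assay, at which 2 of the 3 values shown sit.

The compounds shown leave open how a methyl, a propyl chain, an amine or a carboxylic acid at this carbon would read. Going by these compounds, whether the same exchange acts alike on the core of compound 1 also stays open.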